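The compounds below may be only part of what the source reports. "The series", "measured", "known", "first", "only" and "open" are said of these compounds alone.

Compounds measured in an assay for inhibition of histone deacetylase 8 (Homo sapiens), read by fluorescence, with a stated time of 15 min; a higher number here means a weaker inhibitor, a lower number a stronger inhibitor:
- compound 1 `C[C@@H](N)C(=O)NCc1nnc(-c2ccc(F)cc2)o1`: 116 nM
- compound 2 `Cc1ccc(-c2nnc(CNC(=O)[C@@H](C)N)o2)cc1`: 121 nM
- compound 3 `COc1ccc(-c2nnc(CNC(=O)[C@@H](C)N)o2)cc1`: 153 nM

Compound 3 carries the highest of the three numbers, yet the gap to each neighbour is small: the step from compound 1 to compound 3 is a 1.3-fold higher number from compound 1 to compound 3 (0.12 log units; within the scatter) and that from compound 2 to compound 3 is a 1.3-fold higher number from compound 2 to compound 3 (0.10 log units; within the scatter), both within the scatter. The three compounds differ only in the group placed para to a large group on the six-membered aromatic ring of carbon only, and swapping fluoro for methyl, from compound 1 to compound 2, likewise gave a 1.0-fold higher number from compound 1 to compound 2 (0.02 log units; within the scatter).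

Compound 4 `C[C@@H](N)C(=O)NCc1nnc(-c2ccc([N+](=O)[O-])cc2)o1` takes this series one group further: nitro in place of methoxy on an aromatic carbon. All three measured steps bear on it, since each exchanges the group at the same place, and none moved the number beyond the scatter. Compound 4 is therefore expected to sit close to compound 3, with a step of a 1.0-fold lower number from compound 3 to compound 4 (0.01 log units; within the scatter) in this assay, and its estimated value is 150 nM, within a range of 70 nM to 330 nM.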

Compound 4, half-maximal inhibitory concentration: 127 nM
Estimate against measurement, compound 4: 1.2-fold (0.07 log units) above; the measured number falls inside the stated range.
By their numbers in this assay, from the lowest: compounds 1, 2, 4 and 3 (each within the scatter of the next).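

In this assay, nitro on an aromatic carbon para to a large group cannot be told apart from any of the three earlier groups: the exchange with methoxy gives a 1.2-fold lower number from compound 3 to compound 4 (0.08 log units; within the scatter), that with methyl gives a 1.0-fold higher number from compound 2 to compound 4 (0.02 log units; within the scatter), and that with fluoro gives a 1.1-fold higher number from compound 1 to compound 4 (0.04 log units; within the scatter). All four groups at this place now lie within the scatter of one another, and this holds even for nitro, the only one of them with a double bond outside aromatic rings. Nothing available explains why the number stays so flat here.

The compounds shown leave open whether an amine, a carboxylic acid or a longer chain at this place would move the number beyond the scatter. They also leave open how far a change to the shared core would do so.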